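A Methyl Removed from Two Related Cores

A few compounds are considered here, and "the series" means these few. Any claim that something is new, unique, unknown or untested is made for them only; others in the source may bear on it.

In a functional assay for inhibition, with Homo sapiens as the target (a higher number here means a weaker inhibitor, a lower number a stronger inhibitor), compound 3 `CCCc1nc(C)c2c(C)nn(CC(O)CO)c(=O)n12` reaches only a limit, > 48000 nM. Compound 1 `CCCc1nc(C)c2cnn(CC(O)CO)c(=O)n12` likewise gives only a limit in this assay, > 48000 nM. The step that the two limits leave unreadable from compound 3 to compound 1 therefore cannot be read, since (the limit of > 48000 nM in this assay, at which 3 of the 3 values shown sit). Compound 2 `CCOC(=O)CSc1nncc2c(C)ncn12` also stops at a limit in this assay, > 48000 nM. The difference between the core of compound 2 and the core of compound 3 is not broken down here. Compound 4 `CCOC(=O)CSc1nncc2cncn12` remains to be measured; it differs from compound 2 by hydrogen in place of methyl on an aromatic carbon. This is the same kind of change as hydrogen in place of methyl on an aromatic carbon, though there the place is a six-membered aromatic ring with 3 nitrogen, ortho to a fused ring, meta to a 2,3-dihydroxypropyl group, whereas here it is a five-membered aromatic ring with 2 nitrogen. The expected step that the limit leaves unreadable from compound 2 to compound 4 rests on the limit of compound 2, > 48000 nM. Compound 4 is estimated at 70000 nM, between 20000 nM and 250000 nM, most likely again only a limit.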

Compound 4, half-maximal inhibitory concentration: > 48000 nM
Compound 4 ended at the assay's limit; the forecaster's own chance of this, stated with the estimate: 85%; the middle value lies beyond the limit too.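

Within the data shown here, compound 4, like compound 2, stops at a limit, so no step between them can be read: the limit of > 48000 nM in this assay, at which 4 of the 4 values shown sit. The compounds shown leave open whether hydrogen in place of methyl changes inhibition at all in this assay.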